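Amide variation on the shared core: compound 3

The source may hold more compounds than are shown below. What is called first, only, known or untested is meant among the compounds shown, and "the series" means these compounds.

Going by the values given here, compound 2 `CCN(CC)S(=O)(=O)c1ccc(S(=O)(=O)N2CCC[C@@H](C(=O)N3CCC(F)(F)CC3)C2)cc1` holds the lowest number of the two measured so far: in a functional assay on MIA PaCa-2 cells (Homo sapiens) for inhibition, read by MTT assay, with a stated time of 3 days (a lower number here means a stronger inhibitor, a higher number a weaker inhibitor), compound 2 gives 19 nM. Compound 1 `CCN(CC)S(=O)(=O)c1ccc(S(=O)(=O)N2CCC[C@@H](C(=O)N3CCC(C(F)(F)F)CC3)C2)cc1` gives 110 nM in this assay, and the step of a 5.8-fold lower number from compound 1 to compound 2 (0.76 log units; beyond the scatter) is the only measured one in the set. Compound 3 `CCN(CC)S(=O)(=O)c1ccc(S(=O)(=O)N2CCC[C@@H](C(=O)N[C@@H]3CCOC3)C2)cc1` differs from compound 2 by (oxolan-3-yl)amino in place of 4,4-difluoropiperidin-1-yl on a carbonyl carbon. No measured step touches this change: the one step shown concerns only the substituents on the six-membered ring, and nothing shows what a ring of another size or an amide hydrogen does on this core. Because compound 2 already gives 19 nM the expected direction for compound 3 is towards a higher number, with wide uncertainty, and the step of a 7.9-fold higher number from compound 2 to compound 3 (0.90 log units; beyond the scatter) is the estimated one. The estimate for compound 3 in this assay is 150 nM, within 40 nM to 600 nM.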

Compound 3, half-maximal inhibitory concentration: 100 nM
Estimate against measurement, compound 3: 1.5-fold (0.18 log units) above, within the range that was stated.
By their numbers in this assay, from the lowest: compound 2; then compounds 3 and 1 (each within the scatter of the next).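

In this assay, (oxolan-3-yl)amino on the carbonyl carbon gives a 5.3-fold higher number from compound 2 to compound 3 (0.72 log units; beyond the scatter), so 4,4-difluoropiperidin-1-yl is not matched here by a five-membered ring carrying an amide hydrogen. Set against the other six-membered amide, the same group gives a 1.1-fold lower number from compound 1 to compound 3 (0.04 log units; within the scatter), which leaves the two groups indistinguishable in this assay and compound 2 alone with a clearly lower number. No supporting measurement is available to explain either step.

The step to compound 3 changes ring size, the amide hydrogen and the ring oxygen together, and the compounds shown do not separate these features. Also open, on these data alone, is how a plain piperidin-1-yl, a morpholin-4-yl or the opposite stereoisomer of the (oxolan-3-yl)amino group would read at this position.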